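A few compounds are considered here, and "the series" means these few. Any claim that something is new, unique, unknown or untested is made for them only; others in the source may bear on it.

Measured so far:
- compound 1, `COc1cc(NC2=CC(=O)c3ncncc3C2=O)cc(OC)c1OC`: 1600 nM
- compound 2, `COC(=O)c1ccc(NC2=CC(=O)c3ncncc3C2=O)cc1`: 5800 nM

Both were run in a functional assay on BXPC-3 cells (Homo sapiens) for cytotoxicity, read by MTT assay, with a stated time of 72 h; a lower number here means a stronger inhibitor, a higher number a weaker inhibitor. Compound 1 gives 1600 nM, while compound 2 gives 5800 nM. Compound 2 thus holds the highest of the two numbers; its nearest neighbour is compound 1, whose number is lower by a gap that lies beyond the scatter of repeat measurements. Going by the values given here, nothing further connects the two, as no single-change step between them is available, so the comparison says only that compound 1 is the stronger of the pair.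

The next compound in the series is compound 3, `O=C1C(Nc2ccc(Oc3ccccc3)cc2)=CC(=O)c2ncncc21`. It differs from compound 2 in one place: phenoxy in place of methoxycarbonyl on an aromatic carbon.

Among the compounds with values here, no measured step of this kind exists among the compounds above, so the size of the step rests on the structural change alone. A modest move toward a lower number is expected, of a size near the edge of the scatter, as given by a 2.3-fold lower number from compound 2 to compound 3 (0.37 log units; beyond the scatter). On that basis compound 3 is estimated at 2500 nM, with a range from 800 nM to 8000 nM.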

Compound 3, half-maximal inhibitory concentration: 3600 nM
For compound 3 the middle estimate is 1.4-fold (0.16 log units) below the measured one; measured number inside the range.
By their numbers in this assay, from the lowest: compound 1; then compounds 3 and 2 (each within the scatter of the next).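

At this aromatic carbon, para to a large group, phenoxy in place of methoxycarbonyl gives a 1.6-fold lower number from compound 2 to compound 3 (0.21 log units; within the scatter) in this assay, so this read-out does not separate the two groups. Going by these compounds alone, this is the only single-change step so far, and it shows that a larger group carrying a six-membered aromatic ring of carbon only can replace one with no ring and a double bond outside aromatic rings, without a move beyond the scatter. No measurement shown here bears on why the two groups read alike.

Going by these compounds, whether any group at this position moves the number beyond the scatter stays open: a carboxylic acid, a primary amine, a fluorine or a longer alkoxy chain would test this more widely than one pair can. Within the data shown here, also unresolved is what sets compound 1 apart, since no single-change step links it to compound 2 or compound 3, and its substitution pattern therefore cannot yet be tied to any one position on the ring.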